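Working notes: from compound 2 to compound 4

The source may report more compounds than this note shows. Statements on the series, on what has been measured and on what is new or still open speak of the compounds shown alone.

Measured so far in an assay on COS-7 cells for inhibition of patatin-like phospholipase domain-containing protein 2 (Mus musculus); a higher number here means a weaker inhibitor, a lower number a stronger inhibitor:
- compound 1, `CCOC(=O)c1cc(-c2ccc(OCC)cc2)ccn1`: compound 1 gives 105000 nM
- compound 2, `CCOC(=O)c1cccc(-c2ccc(O)cc2)c1`: compound 2 gives 100000 nM
- compound 3, `CCOC(=O)c1cccc(-c2ccncc2)c1`: compound 3 gives only a limit, > 200000 nM

Compound 2 holds the lowest of the two numbers, with compound 1 within the scatter of it, so no order between them is claimed. Compound 3 sits at the limit (the limit of > 200000 nM in this assay, at which 1 of the 3 values shown sits).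

Compound 4, `CCOC(=O)c1cccc(-c2ccc(CN3CCCC3)cc2)c1`, is not yet measured. It differs from compound 2 by (pyrrolidin-1-yl)methyl in place of hydroxy on an aromatic carbon. Going by the values given here, no measured step in this set covers such a change, so the expectation rests on compound 2 alone. A modest move toward a lower number is expected, a 1.7-fold lower number from compound 2 to compound 4 (0.22 log units; within the scatter), with wide uncertainty. Compound 4 is estimated at 60000 nM, expected between 15000 nM and 200000 nM.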

Compound 4, half-maximal inhibitory concentration: > 200000 nM
Compound 4: no number, only a limit (the forecaster's own chance of this, stated with the estimate: 25%); middle value at least 3.3-fold (0.52 log units) away from the limit.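

In this assay, compound 4 gives only a limit, > 200000 nM. Placing (pyrrolidin-1-yl)methyl in place of hydroxy on this aromatic carbon, para to a large group, gives an at least 2.0-fold higher number from compound 2 to compound 4 (0.30 log units; that floor lies within the scatter), so this change brings no gain at this position, although the floor of that step lies within the scatter. Compound 4 now shares a limit with compound 3: the limit of > 200000 nM in this assay, at which 2 of the 4 values shown sit.

On these data alone, whether a primary amine, a carboxylic acid or a longer chain at this position would give a lower number stays open. As far as these compounds go, the true size of the step also stays open.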